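Longer Amine Arms on a Dicyano Core

The source may report more compounds than this note shows. Statements on the series, on what has been measured and on what is new or still open speak of the compounds shown alone.

Compound 1, `CN(C)CCCn1c(N)c(-c2nc3ccccc3[nH]2)c2nc(C#N)c(C#N)nc21`, is the weakest of the three measured compounds in a functional assay on HeLa cells (Homo sapiens) for antiproliferative activity, read by MTT assay, with a stated time of 48 h (a lower number here means a stronger inhibitor, a higher number a weaker inhibitor), where compound 1 gives 25900 nM. Compound 2, `CCN(CC)CCCn1c(N)c(-c2nc3ccccc3[nH]2)c2nc(C#N)c(C#N)nc21`, carries one change, (diethylamino in place of dimethylamino on a saturated chain carbon, three bonds along the chain from an aromatic nitrogen), and this makes an 8.2-fold lower number from compound 1 to compound 2 (0.91 log units; beyond the scatter). Compound 3, `CN(C)CCCCn1c(N)c(-c2nc3ccccc3n2C)c2nc(C#N)c(C#N)nc21`, stands lowest; in this assay compound 3 gives 460 nM, while compound 2 gives 3150 nM. The difference between the cores of compound 1 and compound 3 is not broken down here.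

Compound 4, `CCN(CC)CCCCn1c(N)c(-c2nc3ccccc3n2C)c2nc(C#N)c(C#N)nc21`, is not yet measured. It differs from compound 3 by diethylamino in place of dimethylamino on a saturated chain carbon, four bonds along the chain from an aromatic nitrogen, the same kind of change as from compound 1 to compound 2, though the place differs: four bonds along the chain rather than three. Because compound 1 to compound 2 gave an 8.2-fold lower number from compound 1 to compound 2 (0.91 log units; beyond the scatter), a lowering is expected, estimated at a 3.1-fold lower number from compound 3 to compound 4 (0.49 log units; beyond the scatter), though smaller, since the surrounding core is different. For compound 4 the expected value is 150 nM, between 50 nM and 500 nM.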

Compound 4, half-maximal inhibitory concentration: 1610 nM
The estimate for compound 4 lay 11-fold (1.03 log units) below the measured number; measured number above the stated range.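

In this assay, the swap of dimethylamino for diethylamino did not lower the number this time, but gave a 3.5-fold higher number from compound 3 to compound 4 (0.54 log units; beyond the scatter). The change therefore does not carry over from one core to the other in this series, and its direction reverses: the same change on two cores in this assay, an 8.2-fold lower number (0.91 log units; beyond the scatter) from compound 1 to compound 2 and a 3.5-fold higher number (0.54 log units; beyond the scatter) from compound 3 to compound 4, 29-fold (1.46 log units) apart, beyond the scatter of two such steps

This does not show what causes the reversal, since the two pairs differ both in the core and in how far along the chain the amine sits, and two steps cannot separate those differences. Open, as far as these compounds go, is whether a ring amine such as pyrrolidine or morpholine, placed on the same chain, would follow compound 3 or compound 4. Also open, from the compounds shown here alone, is how dimethylamino and diethylamino would compare on a longer chain.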